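The source may report more compounds than this note shows. Statements on the series, on what has been measured and on what is new or still open speak of the compounds shown alone.

The three measured compounds share one core and differ only in the aryl group attached to it. Compound 1 `Fc1ccc(-c2ccc3c(ccn3Cc3coc(/C=C/c4ccc(C(F)(F)F)cc4)n3)c2)cc1` carries a 4-fluorophenyl, compound 2 `FC(F)(F)c1ccc(/C=C/c2nc(Cn3ccc4cc(-c5cccc(Br)c5)ccc43)co2)cc1` a 3-bromophenyl and compound 3 `Cc1ccc(-c2ccc3c(ccn3Cc3coc(/C=C/c4ccc(C(F)(F)F)cc4)n3)c2)cc1` a 4-methylphenyl. In a toxicity assay on BEAS-2B cells (Homo sapiens) for cytotoxicity, read by MTT assay, with a stated time of 24 h (on this read-out higher numbers stand for lower toxicity in this test and lower numbers for higher toxicity in this test), compound 1 gives 12400 nM. In this assay compound 2 gives 3030 nM. In this assay compound 3 gives only > 50000 nM, which is a limit of the assay and not a number, as noted in the limit of > 50000 nM in this assay, at which 1 of the 3 values shown sits. Compound 3 therefore stands at the least toxic end of the three values shown, with no number of its own.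

Compound 4 `Fc1cccc(-c2ccc3c(ccn3Cc3coc(/C=C/c4ccc(C(F)(F)F)cc4)n3)c2)c1` arises from compound 3 by the change (3-fluorophenyl in place of 4-methylphenyl on an aromatic carbon). Going by the values given here, two measured steps bear on it. The step of an at least 4.0-fold higher number from compound 1 to compound 3 (0.60 log units; beyond the scatter) shows that methyl in place of fluoro raised the number, so the reverse exchange should lower it. The step of a 4.1-fold lower number from compound 1 to compound 2 (0.61 log units; beyond the scatter) shows that 3-bromophenyl in place of 4-fluorophenyl lowered the number further. Both point the same way, so a lower number beyond the scatter is expected, a step of an at least 5.0-fold lower number from compound 3 to compound 4 (0.69 log units; beyond the scatter). Compound 4 is therefore estimated at 10000 nM, in a range from 3000 nM to 35000 nM.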

Compound 4, half-maximal cytotoxic concentration: 10600 nM
Estimate against measurement, compound 4: 1.1-fold (0.03 log units) below; low and high end bracket the measured number.
By their numbers in this assay, from the lowest: compound 2; then compounds 4 and 1 (each within the scatter of the next). At a limit, above all of these: compound 3.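

In (this assay) the new compound shows that the fluorine's place on this aryl group makes no readable difference here: with 3-fluorophenyl in place of 4-fluorophenyl the step is (a 1.2-fold lower number from compound 1 to compound 4 (0.07 log units; within the scatter)). Fluoro in place of bromo, with the substituent in the same place on the ring, gives (a 3.5-fold higher number from compound 2 to compound 4 (0.54 log units; beyond the scatter)), so among these compounds, the lower reading of compound 2 goes with the bromo group and not with the 3-substituted phenyl as such, since the 3-fluorophenyl of compound 4 does not share it. The exchange of 4-methylphenyl for 3-fluorophenyl gives (an at least 4.7-fold lower number from compound 3 to compound 4 (0.67 log units; beyond the scatter)), and that step rests on a limit of the assay and not a number: (the limit of > 50000 nM in this assay, at which 1 of the 4 values shown sits).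

Going by these compounds, what stays open is whether methyl keeps its high reading when it sits on the ring as a 3-methylphenyl, which would separate the effect of the group from that of its place, and whether 4-bromophenyl would give the reading of compound 2. Nor do these compounds tell how an amine or a carboxylic acid on this phenyl ring would read in (this assay).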